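Swapping a chlorinated phenyl ring for a thiophene ring

The source may report more compounds than this note shows. Statements on the series, on what has been measured and on what is new or still open speak of the compounds shown alone.

In an assay on microsomes from brain for inhibition of Fatty-acid amide hydrolase 1 (Rattus norvegicus), read by fluorescence and HPLC, with a stated time of 60 min (on this read-out higher numbers stand for weaker inhibition and lower numbers for stronger inhibition), compound 2 `CCCCCCCCc1ccc(OCC(=O)Cn2nnc(-c3ccccc3Cl)n2)cc1` gives 32 nM, the second highest of three numbers. Compound 1 `CCCCCCCCc1ccc(OCC(=O)Cn2nnc(-c3ccccc3)n2)cc1` gives 24 nM and compound 3 `CCCCCCCCc1ccc(OCC(=O)Cn2nnc(-c3ccc(S(=O)(=O)N(C)C)cc3)n2)cc1` gives 590 nM. Adding chloro in place of hydrogen on an aromatic carbon gave a 1.3-fold higher number from compound 1 to compound 2 (0.12 log units; within the scatter), while exchanging the whole aromatic group gave an 18-fold higher number from compound 2 to compound 3 (1.27 log units; beyond the scatter). Compound 4 `CCCCCCCCc1ccc(OCC(=O)Cn2nnc(-c3cccs3)n2)cc1` differs from compound 2 in one place: thiophen-2-yl in place of 2-chlorophenyl on an aromatic carbon. Going by the values given here, no measured step replaces this aromatic group with a smaller ring, so the expectation rests on the small change seen in a 1.3-fold higher number from compound 1 to compound 2 (0.12 log units; within the scatter) and on the fact that the large loss in an 18-fold higher number from compound 2 to compound 3 (1.27 log units; beyond the scatter) came with the dimethylsulfamoyl group. A step of about a 1.3-fold higher number from compound 2 to compound 4 (0.10 log units; within the scatter) is therefore expected. Compound 4 is estimated at 40 nM, within 13 nM to 120 nM.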

Compound 4, half-maximal inhibitory concentration: 32 nM
Compound 4: the middle estimate sits 1.3-fold (0.10 log units) above what was measured, and the stated range covers the measured number.
By their numbers in this assay, from the lowest: compounds 1, 2 and 4 (each within the scatter of the next); then compound 3.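

Thiophen-2-yl, a five-membered aromatic ring with a sulfur atom, can take the place of either six-membered ring here without a change beyond the scatter: the swap gives no change at the digits printed from compound 2 to compound 4 (within the scatter) and, against the unsubstituted phenyl, a 1.3-fold higher number from compound 1 to compound 4 (0.12 log units; within the scatter) for the same ring. Measured against 4-(dimethylsulfamoyl)phenyl, it gives an 18-fold lower number from compound 3 to compound 4 (1.27 log units; beyond the scatter), so the large loss seen with compound 3 does not follow from every change of this aromatic group. Nothing available explains these results. As far as these compounds go, whether furan-2-yl, thiophen-3-yl or pyridin-2-yl would fit this position equally well remains open.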